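From Carbamoyl to Tetrazole: An Expected Binding Step

The source may report more compounds than this note shows. Statements on the series, on what has been measured and on what is new or still open speak of the compounds shown alone.

Compound 1 `CC[C@H](C)[C@H](NC(=O)c1cccc(Cn2ccnc2)c1)C(=O)NS(=O)(=O)c1ccccc1` and compound 2 `CC[C@H](C)[C@H](NC(=O)c1cccc(Cn2ccnc2)c1)C(N)=O` share the same core. In an assay on HEK293 cells for displacement of a labelled ligand from Type-2 angiotensin II receptor (Homo sapiens), tested at 10 uM (on this read-out lower numbers stand for a weaker effect and higher numbers for a stronger effect at the one concentration tested), compound 1 gives 24%, whereas compound 2 is reported as "not active" (no number reported), so no number marks where compound 2 stands. Compound 3 `CC[C@H](C)[C@H](NC(=O)c1cccc(Cn2ccnc2)c1)c1nn[nH]n1` carries 2H-tetrazol-5-yl in place of carbamoyl on a saturated chain carbon bound to an amide-type nitrogen and a saturated chain carbon. For the measured compounds named here, no measured pair shows this exact change, so the expectation rests only on compound 1 reaching 24% while compound 2 shows "not active" (no number reported). A modest rise in this assay, beyond the usual scatter, is expected for compound 3, which is estimated at 22%, with a range from 2% to 50%.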

Compound 3, a percentage reported as inhibition, at one concentration (the size of the read-out at that concentration, not a potency): "not active" (no number reported)
Compound 3: no number reported; there is nothing to compare the estimate with.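

Compound 2 and compound 3 are both reported as "not active" without a number in this assay, so no step can be read between them. On these data alone, how far carbamoyl and 2H-tetrazol-5-yl differ in this binding remains open. Nothing available here offers an explanation.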